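Removing the bromine from the most potent of three hydrazones

The source may report more compounds than this note shows. Statements on the series, on what has been measured and on what is new or still open speak of the compounds shown alone.

Compound 3 `O=C(N/N=C\c1cn(Cc2ccc(Cl)cc2)c2ccc(Br)cc12)c1c[nH]c2ccccc12` gives 1000 nM in a functional assay on MDA-MB-231 cells (Homo sapiens) for cytotoxicity (a lower number here means a stronger inhibitor, a higher number a weaker inhibitor), the lowest of the three numbers measured: compound 1 `COc1ccc(Cn2cc(/C=N\NC(=O)c3c[nH]c4ccccc34)c3ccccc32)cc1` gives 15100 nM and compound 2 `COc1ccc2c(c1)c(/C=N\NC(=O)c1c[nH]c3ccccc13)cn2Cc1ccc(Cl)cc1` gives 82700 nM. Compound 4 `O=C(N/N=C\c1cn(Cc2ccc(Cl)cc2)c2ccccc12)c1c[nH]c2ccccc12` differs from compound 3 by hydrogen in place of bromo on an aromatic carbon. Within the data shown here, the one measured step at that position, an 83-fold lower number from compound 2 to compound 3 (1.92 log units; beyond the scatter), shows that the group there matters greatly. Among the measured compounds shown here, no measured pair compares bromo with hydrogen, yet compound 1, which also carries hydrogen at that position, gives a much higher number than compound 3. Losing the bromo is therefore expected to raise the number, as an 8.0-fold higher number from compound 3 to compound 4 (0.90 log units; beyond the scatter). Compound 4 is expected to give about 8000 nM, with a likely range from 2000 nM to 40000 nM.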

Compound 4, half-maximal inhibitory concentration: 66400 nM
Compound 4: the middle estimate sits 8.3-fold (0.92 log units) below what was measured; the whole stated range lies below it.
By their numbers in this assay, from the lowest: compound 3; then compound 1; then compounds 4 and 2 (each within the scatter of the next).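

In this assay the low number belongs to the bromo itself: hydrogen in its place gives a 66-fold higher number from compound 3 to compound 4 (1.82 log units; beyond the scatter) and so loses all that the bromo brought. Hydrogen and methoxy at this position cannot be told apart, with a 1.2-fold lower number from compound 2 to compound 4 (0.10 log units; within the scatter) inside the scatter, so bromo alone of the three groups stands out here. A separate change, chloro in place of methoxy, gives a 4.4-fold higher number from compound 1 to compound 4 (0.64 log units; beyond the scatter) and is a modest step. As far as these compounds go, whether an iodo or a methyl group at the bromo position would also keep the number low stays open. Nothing measured here explains what the bromo does.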